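Benzyl for 4-chlorophenyl on the ring amine nitrogen

A few compounds are considered here, and "the series" means these few. Any claim that something is new, unique, unknown or untested is made for them only; others in the source may bear on it.

Measured so far:
- compound 1 `Nc1ccccc1NC(=O)c1ccc(CSC(=S)N2CCN(c3ccc(Cl)cc3)CC2)cc1` gives 29% in a functional assay on A-375 cells (Homo sapiens) for antiproliferative activity, read by CCK-8 assay, with a stated time of 72 h, tested at 8 uM; on this read-out lower numbers stand for a weaker effect and higher numbers for a stronger effect at the one concentration tested
- compound 2 `Nc1ccccc1NC(=O)c1ccc(CSC(=S)N2CCc3ccc([N+](=O)[O-])cc32)cc1` gives 42% in this assay

Compound 1 stands lowest of the two numbers measured; compound 2 is its nearest neighbour, and the gap between them lies beyond the usual scatter. Among the compounds with values here, the two compounds differ in more than one place, so no single step is defined between them and nothing is read from their difference beyond what the two values show.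

Compound 3 `Nc1ccccc1NC(=O)c1ccc(CSC(=S)N2CCN(Cc3ccccc3)CC2)cc1` is not yet measured. It differs from compound 1 as follows: benzyl in place of 4-chlorophenyl on an amine nitrogen in a ring. Within the data shown here, no measured pair shows this change, so no step of known size or direction is on hand. The expectation is therefore a step in this assay of no size beyond the scatter, in either direction. Compound 3 is estimated at 31% (range 16% to 48%), which means an expected step of a number 2 percentage points higher from compound 1 to compound 3 (within the scatter).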

Compound 3, a percentage reported as inhibition, at one concentration (the size of the read-out at that concentration, not a potency): 29.3%
Compound 3: middle estimate off by 1.7 percentage points, on the high side; the range from low to high includes it.
By their numbers in this assay, from the lowest: compounds 1 and 3 (each within the scatter of the next); then compound 2.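

In this assay, within the data shown here, benzyl in place of 4-chlorophenyl on the amine nitrogen in the ring gives the first step that can be read on its own (a number 0.3 percentage points higher from compound 1 to compound 3 (within the scatter)). At the one concentration tested, the read-out does not separate these two groups, which have the same count of heavy atoms and each carry one six-membered aromatic ring of carbon only. No measurement bearing on this result offers an explanation for it.

Going by these compounds, whether a longer chain such as phenethyl, or a carboxylic acid or an amine on the aromatic ring, would shift the read-out at this nitrogen remains open. A reading at one concentration also leaves open whether compound 1 and compound 3 would match in potency.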